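The source may hold more compounds than are shown below. What is called first, only, known or untested is meant among the compounds shown, and "the series" means these compounds.

Measured so far:
compound 1 `CCCCCC(C)OC(=O)CC(=O)Nc1c(C(C)C)cccc1C(C)C`: 27 nM
compound 2 `CC(C)c1cccc(C(C)C)c1NC(=O)CC(=O)OC(C)(C)C`: 130 nM
compound 3 `CCCCCCOC(=O)CC(=O)Nc1c(C(C)C)cccc1C(C)C`: 810 nM

In an assay on microsomes from intestine for inhibition of acyl-CoA:cholesterol acyltransferase (Oryctolagus cuniculus) (a higher number here means a weaker inhibitor, a lower number a stronger inhibitor), compound 3 gives the highest number of the three; compound 2 stands nearest (a 6.2-fold higher number from compound 2 to compound 3 (0.79 log units; beyond the scatter)) and compound 1 furthest (a 30-fold higher number from compound 1 to compound 3 (1.48 log units; beyond the scatter)). Compound 4 `CCCCCCCCOC(=O)CC(=O)Nc1c(C(C)C)cccc1C(C)C` differs from compound 3 by ethyl in place of hydrogen on a saturated chain carbon, six bonds along the chain from an oxygen next to a carbonyl group. For the measured compounds named here, no measured step alters the chain at that place. The two steps ending at compound 3, a 6.2-fold higher number from compound 2 to compound 3 (0.79 log units; beyond the scatter) and a 30-fold higher number from compound 1 to compound 3 (1.48 log units; beyond the scatter), both change the group on the oxygen next to the carbonyl group and both raise the number, but neither lengthens a chain at its far end, so they give no firm direction. The expectation is therefore a 1.6-fold lower number from compound 3 to compound 4 (0.21 log units; within the scatter), with a wide range. Compound 4 is expected to give 500 nM in this assay, between 120 nM and 2500 nM.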

Compound 4, half-maximal inhibitory concentration: 260 nM
Compound 4: the middle estimate sits 1.9-fold (0.28 log units) above what was measured; low and high end bracket the measured number.
By their numbers in this assay, from the lowest: compound 1; then compounds 2 and 4 (each within the scatter of the next); then compound 3.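

In the series, ethyl in place of hydrogen at this far position, six bonds along the chain from the oxygen, changes the result in this assay (a 3.1-fold lower number from compound 3 to compound 4 (0.49 log units; beyond the scatter)), so lengthening hexyl to octyl lowers the number. Octyl still leaves compound 4 within the scatter of the tert-butyl compound (a 2.0-fold higher number from compound 2 to compound 4 (0.30 log units; within the scatter)) and well short of the 1-methylhexyl compound (a 9.6-fold higher number from compound 1 to compound 4 (0.98 log units; beyond the scatter)). Nothing available accounts for the effect of the added ethyl.

On these data alone, whether a longer chain such as decyl lowers the number further remains open. So does whether a methyl branch on the octyl chain adds to the lengthening.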